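From 3-chlorophenyl to 4-chlorophenyl: a small expected step

This account rests on a few compounds, and the source may have more. Where it says the series, first, only, none or still open, it means among the compounds named here.

- Compound 1 `CC1=CC[C@@H]([C@@](C)(O)CCCC(C)(C)NC(=S)N/N=C\c2ccccc2[N+](=O)[O-])CC1` gives 7390 nM
- Compound 2 `CC1=CC[C@@H]([C@@](C)(O)CCCC(C)(C)NC(=S)N/N=C\c2cccc(Cl)c2)CC1` gives 8270 nM

In a functional assay on OVCAR-3 cells (Homo sapiens) for cytotoxicity, read by sulforhodamine B assay (on this read-out higher numbers stand for weaker inhibition of growth and lower numbers for stronger inhibition of growth), compound 2 at 8270 nM stands level with compound 1 within the scatter. Compound 3 `CC1=CC[C@@H]([C@@](C)(O)CCCC(C)(C)NC(=S)N/N=C\c2ccc(Cl)cc2)CC1` differs from compound 2 in one place: 4-chlorophenyl in place of 3-chlorophenyl on a carbon with a double bond to nitrogen. Going by the values given here, only one measured step bears on this change, and it touched the same place: a 1.1-fold higher number from compound 1 to compound 2 (0.05 log units; within the scatter). Among the compounds with values here, that swap of 2-nitrophenyl for 3-chlorophenyl stayed within the scatter, but no measurement yet tests 4-chlorophenyl. No shift beyond the scatter is therefore expected in this assay, and the expected change is a 1.1-fold lower number from compound 2 to compound 3 (0.03 log units; within the scatter). For compound 3 the estimated value is 7800 nM, with an expected range of 3800 nM to 15000 nM.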

Compound 3, concentration for 50% growth inhibition: 6660 nM
Compound 3: the middle estimate sits 1.2-fold (0.07 log units) above what was measured, and the stated range covers the measured number.
By their numbers in this assay, from the lowest: compounds 3, 1 and 2 (each within the scatter of the next).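

In this assay, 4-chlorophenyl in place of 3-chlorophenyl gives a 1.2-fold lower number from compound 2 to compound 3 (0.09 log units; within the scatter) and 4-chlorophenyl in place of 2-nitrophenyl gives a 1.1-fold lower number from compound 1 to compound 3 (0.05 log units; within the scatter), so both steps stay within the scatter. On this carbon with a double bond to nitrogen, the two chlorophenyl groups therefore read alike, and neither reads apart from 2-nitrophenyl. No supporting evidence bears on why this result arises. Still open, as far as these compounds go, is whether a pyridine ring, or a phenyl ring carrying an amine or a carboxylic acid, would move the number beyond the scatter.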